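A few compounds are considered here, and "the series" means these few. Any claim that something is new, unique, unknown or untested is made for them only; others in the source may bear on it.

Compound 2 `COc1cc(/C=N/NC(=O)Nc2ccc(Oc3ccnc(-c4nncn4CCN(C)C)c3)c(F)c2)ccc1O` gives the lowest of the two numbers recorded so far in a functional assay on NCI-H460 cells (Homo sapiens) for cytotoxicity, read by MTT assay, with a stated time of 72 h (on this read-out higher numbers stand for weaker inhibition and lower numbers for stronger inhibition), at 57 nM. Compound 1 `CN(C)CCn1cnnc1-c1cc(Oc2ccc(NC(=O)N/N=C/c3ccc(F)cc3)cc2F)ccn1` gives 1980 nM in this assay. Within the data shown here, the one measured step, a 35-fold lower number from compound 1 to compound 2 (1.54 log units; beyond the scatter), came from putting 4-hydroxy-3-methoxyphenyl in place of 4-fluorophenyl on a carbon with a double bond to nitrogen. Compound 3 `CN(C)CCn1cnnc1-c1cc(Oc2ccc(NC(=O)N/N=C/c3cccc(O)c3)cc2F)ccn1` differs from compound 2 by 3-hydroxyphenyl in place of 4-hydroxy-3-methoxyphenyl on a carbon with a double bond to nitrogen. This removes part of the group that brought the large drop, so a moderately higher number is expected, a 4.4-fold higher number from compound 2 to compound 3 (0.64 log units; beyond the scatter). For compound 3 the estimate is 250 nM, within 80 nM to 800 nM.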

Compound 3, half-maximal inhibitory concentration: 780 nM
Compound 3: middle estimate off by 3.1-fold (0.49 log units), on the low side, within the range that was stated.
By their numbers in this assay, from the lowest: compound 2; then compound 3; then compound 1.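

In this assay the swap of 4-hydroxy-3-methoxyphenyl for 3-hydroxyphenyl gives a 14-fold higher number from compound 2 to compound 3 (1.14 log units; beyond the scatter) and so shows that a single hydroxy group on this ring does not keep the low number of compound 2. Measured against 4-fluorophenyl, the 3-hydroxyphenyl group still gives a 2.5-fold lower number from compound 1 to compound 3 (0.40 log units; beyond the scatter) and so holds only a modest part of the large gain. No available evidence bears on the reason for these differences. Still open, from the compounds shown here alone, is whether 4-hydroxyphenyl, 3-methoxyphenyl or an aminophenyl group at this place would match compound 2.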